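Sulfonyl for carbonyl on the amide nitrogen of the series

The source may report more compounds than this note shows. Statements on the series, on what has been measured and on what is new or still open speak of the compounds shown alone.

Compound 1 `CN(C(=O)C(C)(C)C)c1ccc2[nH]c(-c3n[nH]c4ccccc34)cc2n1`, compound 2 `CN(C(=O)c1ccc(F)cc1)c1ccc2[nH]c(-c3n[nH]c4ccccc34)cc2n1` and compound 3 `COc1cccc(C(=O)N(C)c2ccc3[nH]c(-c4n[nH]c5ccccc45)cc3n2)c1` share one core and differ only in the group on the carbonyl carbon. In a functional assay on HCT-116 cells (Homo sapiens) for antiproliferative activity, read by MTT assay, with a stated time of 72 h (a higher number here means a weaker inhibitor, a lower number a stronger inhibitor), compound 1 gives 18000 nM, compound 2 gives 9270 nM and compound 3 gives 14200 nM. The steps of a 1.9-fold lower number from compound 1 to compound 2 (0.29 log units; within the scatter), a 1.3-fold lower number from compound 1 to compound 3 (0.10 log units; within the scatter) and a 1.5-fold higher number from compound 2 to compound 3 (0.19 log units; within the scatter) all stay within the scatter, so compound 3 is not separated from either neighbour. Compound 4 `Cc1ccc(S(=O)(=O)N(C)c2ccc3[nH]c(-c4n[nH]c5ccccc45)cc3n2)cc1` brings ((4-methylphenyl)sulfonyl in place of (3-methoxyphenyl)carbonyl on a nitrogen on an aromatic ring). For the measured compounds named here, no measured step replaces the carbonyl itself, and the three steps among aryl and alkyl groups on it were all small. For compound 4 the estimated step of a 1.2-fold lower number from compound 3 to compound 4 (0.07 log units; within the scatter) is therefore expected to stay within the scatter, and compound 4 is expected near 12000 nM, between 4000 nM and 40000 nM.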

Compound 4, half-maximal inhibitory concentration: 13300 nM
Compound 4: middle estimate off by 1.1-fold (0.04 log units), on the low side, and the stated range covers the measured number.
By their numbers in this assay, from the lowest: compounds 2, 4, 3 and 1 (each within the scatter of the next).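

In this assay the change at this nitrogen now reaches the linking group itself, and sulfonyl in place of carbonyl stays within the scatter against all three amides (a 1.1-fold lower number from compound 3 to compound 4 (0.03 log units; within the scatter)) and (a 1.4-fold higher number from compound 2 to compound 4 (0.16 log units; within the scatter)) and (a 1.4-fold lower number from compound 1 to compound 4 (0.13 log units; within the scatter)). The aryl group changes in the same step from compound 3 to compound 4, so the linker and the ring substituents are not separated here. No measurement at hand explains this result.

As far as these compounds go, whether a methylsulfonyl group, or a carboxylic acid on the aryl ring, would move the number beyond the scatter remains open. From the compounds shown here alone, the effect of hydrogen in place of the methyl on this nitrogen also remains open.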